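Cell tolerance notes on compounds 1 to 4

The source may hold more compounds than are shown below. What is called first, only, known or untested is meant among the compounds shown, and "the series" means these compounds.

Measured in an ADME assay on LLC-MK2 cells (Macaca mulatta) for cytotoxicity, read by sulforhodamine B assay, with a stated time of 96 h; a higher number here means that more compound is tolerated, a lower number that less compound is tolerated:
- compound 1 `C=C1CC[C@@H]2[C@](C)(CCC[C@@]2(C)C(=O)O)[C@H]1CCc1ccoc1` gives 60100 nM
- compound 2 `C=C1CC[C@@H]2C(C)(C)CCC[C@@]2(C)[C@@H]1CC/C(C)=C/C(=O)O` gives 39400 nM
- compound 3 `C=C1CC[C@@H]2C(C)(C)[C@@H](O)CC[C@@]2(C)[C@@H]1CC/C(C)=C/C(=O)O` gives 31200 nM

Compound 1 has the highest of the three numbers in this assay, but its gap to compound 2 and to compound 3 both sit within the scatter, so no order among the three can be claimed. Compound 4 `C=C1CC[C@@H]2[C@](C)(CCC[C@@]2(C)C(=O)O)[C@H]1CC[C@H](C)CC(=O)O` has not yet been measured. Relative to compound 1 the change is 1-(carboxymethyl)ethyl in place of furan-3-yl on a saturated chain carbon, two bonds along the chain from a saturated ring carbon. Among the measured compounds shown here, the only measured step is a 1.3-fold lower number from compound 2 to compound 3 (0.10 log units; within the scatter), a different kind of change on a different part of the molecule; it gives no guidance on a change at the chain end. For the measured compounds named here, no pair among the measured compounds swaps the furan-3-yl group for 1-(carboxymethyl)ethyl. All three measured numbers lie within the scatter of one another despite differences in their side chains, so for compound 4 no step beyond the scatter is expected, and the step of a 1.2-fold lower number from compound 1 to compound 4 (0.08 log units; within the scatter) is the estimate. Compound 4 is expected to give 50000 nM in this assay, within 20000 nM to 130000 nM.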

Compound 4, half-maximal cytotoxic concentration: 252000 nM
Estimate against measurement, compound 4: 5.0-fold (0.70 log units) below; the whole stated range lies below it.
By their numbers in this assay, from the lowest: compounds 3, 2 and 1 (each within the scatter of the next); then compound 4.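

In this assay, swapping furan-3-yl for 1-(carboxymethyl)ethyl on a saturated chain carbon, two bonds along the chain from a saturated ring carbon, gives a 4.2-fold higher number from compound 1 to compound 4 (0.62 log units; beyond the scatter). The only earlier step, a 1.3-fold lower number from compound 2 to compound 3 (0.10 log units; within the scatter), stayed within the scatter and lay elsewhere on the molecule, so this is the first place in the series shown to move the number beyond it. Nothing measured here accounts for the shift.

This single swap removes the furan-3-yl ring and adds the carboxymethyl end together, so the compounds shown do not separate the two, nor do they show what the defined stereocentre of the new group contributes. Also open, going by these compounds, is whether a plain butyl group or an amine at the chain end would give a similar step.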